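Swapping the aryl group on a purine-type adenosine ligand

The source may report more compounds than this note shows. Statements on the series, on what has been measured and on what is new or still open speak of the compounds shown alone.

Measured so far:
Compound 1, `Cn1c(-c2cccc(Cl)c2)nc2c(NC3CCCC3)ncnc21`: in an assay on CHO cells for displacement of a labelled ligand from adenosine receptor A3 (Homo sapiens), read by scintillation counting, with a stated time of 3 h (a lower number here means a stronger inhibitor, a higher number a weaker inhibitor), compound 1 gives 514 nM
Compound 2, `CCCn1c(-c2ccccc2)nc2c(NC3CCOC3)ncnc21`: in this assay compound 2 gives 2810 nM

Compound 1 has the lower of the two numbers; compound 2 sits well above it, and that gap is beyond the usual scatter of repeated measurements. The two differ in several places at once, so nothing can be read into any single part of the difference.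

Compound 3, `Cc1ccc(-c2nc3c(NC4CCCC4)ncnc3n2C)cc1`, is not yet measured. It keeps the core of compound 1 and changes only the aryl group: 4-methylphenyl in place of 3-chlorophenyl on an aromatic carbon. Within the data shown here, no measured pair shows the effect of such a swap, so the expectation rests on a single starting point. The step from compound 1 to compound 3 is expected to be small, a 1.6-fold higher number from compound 1 to compound 3 (0.19 log units; within the scatter), leaning towards a weaker inhibitor but quite possibly within the scatter. Compound 3 is therefore estimated at 800 nM, with a likely range from 250 nM to 2500 nM.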

Compound 3, inhibition constant: 480 nM
For compound 3 the middle estimate is 1.7-fold (0.22 log units) above the measured one, within the range that was stated.
By their numbers in this assay, from the lowest: compounds 3 and 1 (each within the scatter of the next); then compound 2.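

Putting 4-methylphenyl in place of 3-chlorophenyl on this aromatic carbon gives a 1.1-fold lower number from compound 1 to compound 3 (0.03 log units; within the scatter) in this assay. Among these compounds, this is the first change in a single place, and it shows that this assay does not separate these two aryl groups when the rest of the core of compound 1 stays the same, even though one carries a chlorine and the other a methyl group at a different ring position. Nothing available here explains why the two compounds read alike.

This single pair cannot show whether the position would accept a very different group, such as a phenyl ring carrying an amine or a carboxylic acid. It also leaves open whether a longer chain, such as butyl, on the ring atom that bears the methyl group would alter the reading.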